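A few compounds are considered here, and "the series" means these few. Any claim that something is new, unique, unknown or untested is made for them only; others in the source may bear on it.

Measured compounds:
compound 1 `COc1ccc(C2=NN(C3=NC(=O)/C(=C4\C(=O)Nc5ccc(Br)cc54)S3)C(c3ccc(OC)cc3)C2)cc1` gives 210 nM in a functional assay on cells (Cancer cell lines, Homo sapiens) for cytotoxicity, read by sulforhodamine B assay, with a stated time of 48 h; a lower number here means a stronger inhibitor of growth, a higher number a weaker inhibitor of growth
compound 2 `COc1ccc(C2CC(c3ccc4ccccc4c3)=NN2C2=NC(=O)/C(=C3\C(=O)Nc4ccccc43)S2)cc1` gives 5960 nM in this assay

For the measured compounds named here, compound 2 carries the higher of the two numbers in this assay; compound 1, its only neighbour, sits at a lower number, and the gap between them is beyond the scatter of the method. The two differ in several places at once. These two values alone do not show how much of that gap goes with any one of those changes.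

Compound 3 `COc1ccc(C2CC(c3ccc4ccccc4c3)=NN2C2=NC(=O)/C(=C3\C(=O)Nc4ccc(Br)cc43)S2)cc1` is compound 2 with one change: bromo in place of hydrogen on an aromatic carbon. Going by the values given here, no measured pair shows this step on its own. Among the compounds with values here, the only bromo-bearing compound, compound 1, also differs from compound 2 elsewhere, so the direction is uncertain; a modest shift toward a lower number is expected, within or just beyond the scatter. For compound 3 the expected step is a 2.4-fold lower number from compound 2 to compound 3 (0.38 log units; beyond the scatter). Compound 3 is therefore estimated at 2500 nM, with a range from 800 nM to 8000 nM.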

Compound 3, concentration for 50% growth inhibition: 61 nM
Beside the measured number, compound 3's estimate is 41-fold (1.61 log units) above it; the whole stated range lies above it.
By their numbers in this assay, from the lowest: compound 3; then compound 1; then compound 2.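

In this assay, bromo in place of hydrogen on an aromatic carbon of the six-membered ring of carbon only, part of a fused system of two rings, gives a 98-fold lower number from compound 2 to compound 3 (1.99 log units; beyond the scatter), so this change can now be read on its own, and it is a large step. With bromo present on both sides, naphthalen-2-yl in place of 4-methoxyphenyl on the carbon with a double bond to nitrogen gives a 3.4-fold lower number from compound 1 to compound 3 (0.54 log units; beyond the scatter), a modest step and much the smaller of the two. No measurement in hand accounts for either step.

The compounds shown leave open whether the bromo step stays as large when 4-methoxyphenyl stands in place of naphthalen-2-yl, as this single pair reads it with naphthalen-2-yl only. They also leave open whether chloro, fluoro or methoxy on that same aromatic carbon would go with a step of similar size, or whether the gain belongs to bromo alone.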